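Same atoms, joined differently: from compound 2 to compound 3

The compounds below may be only part of what the source reports. "The series", "measured", "known", "first", "only" and "open" are said of these compounds alone.

Compound 1 `COc1ccc([C@H]2CC(=O)N(c3ccc(C)cc3)C2)cc1OC1CCCC1` gives > 10000 nM as a limit
Compound 2 `COc1ccc([C@H]2CC(=O)N(c3cccc([S+](C)[O-])c3)C2)cc1OC1CCCC1` gives > 10000 nM as a limit

In a functional assay on HEK293 cells (Homo sapiens) for cytotoxicity (a lower number here means that less compound is tolerated, a higher number that more compound is tolerated), compound 2 gives > 10000 nM as a limit of the assay and not as a number. The evidence so far is the limit of > 10000 nM in this assay, at which 2 of the 2 values shown sit, and no number. Compound 3 `COc1ccc([C@H]2CC(=O)N(c3ccc([S+](C)[O-])cc3)C2)cc1OC1CCCC1` has the same atoms as compound 2, joined differently (a group of 9 heavy atoms (7 carbon, 1 oxygen, 1 sulfur; one six-membered aromatic ring of carbon only) in place of a group of 9 heavy atoms (7 carbon, 1 oxygen, 1 sulfur; one six-membered aromatic ring of carbon only), on an amide-type nitrogen in a ring). Going by the values given here, the only measured step nearby is a step that the two limits leave unreadable from compound 1 to compound 2 and gives no size to carry over, so no step beyond the usual scatter is expected in this assay and another limit is likely. The estimated step is a step that the limit leaves unreadable from compound 2 to compound 3 and remains an expectation. For compound 3 the expected value is 15000 nM with an estimated range from 10000 nM to 30000 nM until it is measured.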

Compound 3, half-maximal cytotoxic concentration: 7510 nM
For compound 3 the middle estimate is 2.0-fold (0.30 log units) above the measured one; the whole stated range lies above it.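

In this assay, going by these compounds alone, compound 3 gives the first true number in this set, 7510 nM. Joining the same atoms differently on the aromatic ring gives an at least 1.3-fold lower number from compound 2 to compound 3 (0.12 log units; that floor lies within the scatter), and exchanging the group on the aromatic carbon gives an at least 1.3-fold lower number from compound 1 to compound 3 (0.12 log units; that floor lies within the scatter). Both sizes are only floors, the step from compound 1 to compound 2 cannot be read, and the comparison still rests on a limit: the limit of > 10000 nM in this assay, at which 2 of the 3 values shown sit. Going by these compounds, how far the number would fall with no limit in the comparison stays open. So does the number that an amine or a carboxylic acid on the same aromatic ring would give.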